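Cinnamamide and caffeate ester series: working notes toward compound 4

A few compounds are considered here, and "the series" means these few. Any claim that something is new, unique, unknown or untested is made for them only; others in the source may bear on it.

Measured so far in a functional assay on ECa-109 cells (Homo sapiens) for cytotoxicity, read by MTT assay, with a stated time of 72 h; on this read-out higher numbers stand for weaker inhibition and lower numbers for stronger inhibition:
- compound 1 `COCOc1ccc(/C=C/C(=O)N2CCN(Cc3ccc(Cl)c(Cl)c3)CC2)cc1OCOC`: 7400 nM
- compound 2 `CCOc1ccc(COc2c(OC)cc(/C=C/C(=O)N3CCN(Cc4ccc(Cl)c(Cl)c4)CC3)cc2OC)cc1`: 1100 nM
- compound 3 `O=C(COC(=O)/C=C/c1ccc(O)c(O)c1)NN1CCOCC1`: > 200000 nM

Compound 1 and compound 2 share the piperazine cinnamamide core and give numbers within the measured range in this assay. For the measured compounds named here, compound 3 sits apart, as a caffeate glycolamide ester with a morpholinyl amino group on the amide; no single-point step links it to compound 1 or compound 2, so the three values are simply read side by side. For compound 3 the value in this assay is a limit and not a number, as recorded in the limit of > 200000 nM in this assay, at which 1 of the 3 values shown sits: compound 3 stands at the weak end of what has been measured.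

The next compound, compound 4 `O=C(COC(=O)/C=C/c1ccc(O)c(O)c1)Nc1ccc(Cl)cc1`, keeps the caffeate glycolamide ester and differs from compound 3 only on the amide nitrogen: 4-chlorophenyl in place of morpholin-4-yl on an amide-type nitrogen. Going by the values given here, no measured step gives the size of such a change. Since compound 3 is known only as a limit, the step to compound 4 is expected to be either within scatter or towards stronger inhibition, with a fair chance that compound 4 again returns only a limit.

Compound 4 is expected to give about 80000 nM in this assay, between 15000 nM and 300000 nM, which would mean an estimated step of an at least 2.5-fold lower number from compound 3 to compound 4 (0.39 log units; beyond the scatter).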

Compound 4, half-maximal inhibitory concentration: 175000 nM
For compound 4 the middle estimate is 2.2-fold (0.34 log units) below the measured one; low and high end bracket the measured number.
By their numbers in this assay, from the lowest: compound 2; then compound 1; then compound 4. At a limit, above all of these: compound 3.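

On the amide-type nitrogen, whose other neighbour is the carbonyl carbon, 4-chlorophenyl in place of morpholin-4-yl gives in this assay an at least 1.1-fold lower number from compound 3 to compound 4 (0.05 log units; that floor lies within the scatter), so this change is not shown to move the read-out beyond the scatter. The caffeate glycolamide ester series now has a measured number, with compound 4 at 175000 nM in this assay, and this position has been read with both a non-aromatic ring carrying hetero atoms and an aromatic ring of carbon only. Compound 3 is known only as a limit, so the step has a floor and no measured size: the limit of > 200000 nM in this assay, at which 1 of the 4 values shown sits.

Still open, as far as these compounds go, is whether the chlorine of the 4-chlorophenyl group contributes anything, which an unsubstituted phenyl on the same nitrogen would address, and whether a group such as 4-methoxyphenyl or a benzyl on that nitrogen would give a clearly lower number in this assay. Also open, from the compounds shown here alone, is how the caffeate glycolamide ester would read with a single change at its catechol, such as methoxy groups in place of the two hydroxyl groups.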